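Moving the Thiophene Attachment Point in Compound 2

The source may report more compounds than this note shows. Statements on the series, on what has been measured and on what is new or still open speak of the compounds shown alone.

In a functional assay on HCT-15 cells (Homo sapiens) for cytotoxicity, read by CCK-8 assay and cell counting, with a stated time of 2 days (on this read-out higher numbers stand for weaker inhibition and lower numbers for stronger inhibition), compound 2 `Oc1cccc(-c2cc(-c3ccsc3)nc(-c3ccccc3Cl)c2)c1` gives 2500 nM, the lowest of the three numbers shown. Compound 3 `Oc1cccc(-c2cc(-c3ccsc3)nc(-c3cccc(Cl)c3)c2)c1` gives 2510 nM, and the step of a 1.0-fold higher number from compound 2 to compound 3 (0.00 log units; within the scatter) is within the scatter, so these two cannot be told apart. Compound 1 `Oc1cccc(-c2cc(-c3ccc(Cl)cc3)nc(-c3cccs3)c2)c1` gives 9280 nM, the number furthest from compound 2 and beyond the scatter. The unmeasured compound 4 `Oc1cccc(-c2cc(-c3cccs3)nc(-c3ccccc3Cl)c2)c1` differs from compound 2 by thiophen-2-yl in place of thiophen-3-yl on an aromatic carbon. Within the data shown here, no measured step isolates this change: compound 1 carries thiophen-2-yl but differs from compound 2 in a second place as well, so its higher number cannot be credited to the thiophene alone. A modest step toward a higher number is therefore expected, as a 1.4-fold higher number from compound 2 to compound 4 (0.15 log units; within the scatter). Compound 4 is estimated at 3500 nM, within 1500 nM to 9000 nM.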

Compound 4, half-maximal inhibitory concentration: 2790 nM
The estimate for compound 4 lay 1.3-fold (0.10 log units) above the measured number; low and high end bracket the measured number.
By their numbers in this assay, from the lowest: compounds 2, 3 and 4 (each within the scatter of the next); then compound 1.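

In this assay, thiophen-2-yl in place of thiophen-3-yl gives a 1.1-fold higher number from compound 2 to compound 4 (0.05 log units; within the scatter), so the two thiophene attachment points cannot be told apart beside a 2-chlorophenyl group. With 2-chlorophenyl in place of 4-chlorophenyl, the data show a 3.3-fold lower number from compound 1 to compound 4 (0.52 log units; beyond the scatter), so the gap to compound 1 goes with the 4-chlorophenyl group rather than with the thiophene. Nothing available explains either result. Still open, going by these compounds, is how a furan-2-yl group or an aminomethyl group would fare in place of the thiophene, and whether 4-chlorophenyl gives a similar gap beside thiophen-3-yl.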